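A Trimethoxyphenyl Group Replaces Phenylethenyl on the Saturated Carbon

The compounds below may be only part of what the source reports. "The series", "measured", "known", "first", "only" and "open" are said of these compounds alone.

Among the three measured compounds, compound 3 `Cc1cc(O)c(C2=NN(c3ccc(S(N)(=O)=O)cc3)C(/C=C/c3ccccc3)C2)cc1Cl` stands highest in a functional assay on NCI-H522 cells (Homo sapiens) for antiproliferative activity, with a stated time of 48 h (on this read-out lower numbers stand for stronger inhibition of growth and higher numbers for weaker inhibition of growth), giving 19400 nM. Compound 1 `Cc1cc(O)c(C2=NN(c3ccc(S(N)(=O)=O)cc3)C(c3ccccc3O)C2)cc1Cl` gives 6280 nM and compound 2 `Cc1cc(O)c(C2=NN(c3ccc(S(N)(=O)=O)cc3)C(c3ccccc3Cl)C2)cc1Cl` gives 3970 nM; the step of a 1.6-fold lower number from compound 1 to compound 2 (0.20 log units; within the scatter) separates them. Compound 4 `COc1ccc(C2CC(c3cc(Cl)c(C)cc3O)=NN2c2ccc(S(N)(=O)=O)cc2)c(OC)c1OC` differs from compound 3 by 2,3,4-trimethoxyphenyl in place of 2-phenylethenyl on a saturated ring carbon. The earlier steps shown here that bear on this run the other way: a 3.1-fold higher number from compound 1 to compound 3 (0.49 log units; beyond the scatter) and a 4.9-fold higher number from compound 2 to compound 3 (0.69 log units; beyond the scatter), so placing 2-phenylethenyl on that carbon in place of an aryl group raised the number each time. Returning an aryl group to that position is therefore expected to lower the number by a modest amount, estimated as a 3.9-fold lower number from compound 3 to compound 4 (0.59 log units; beyond the scatter). Compound 4 is expected to give about 5000 nM in this assay, within a range from 2000 nM to 15000 nM.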

Compound 4, concentration for total growth inhibition: 6730 nM
The estimate for compound 4 lay 1.3-fold (0.13 log units) below the measured number; the range from low to high includes it.
By their numbers in this assay, from the lowest: compounds 2, 1 and 4 (each within the scatter of the next); then compound 3.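

In this assay, 2,3,4-trimethoxyphenyl on the saturated ring carbon also gives a lower number than 2-phenylethenyl, a 2.9-fold lower number from compound 3 to compound 4 (0.46 log units; beyond the scatter), so all three aryl groups shown do so. The three methoxy groups do not separate it from the other aryl groups: a 1.7-fold higher number from compound 2 to compound 4 (0.23 log units; within the scatter) and a 1.1-fold higher number from compound 1 to compound 4 (0.03 log units; within the scatter) both lie within the scatter, so these three cannot be ranked. No measurement available here accounts for these steps. From the compounds shown here alone, whether a cyclohexyl group or a pyridine ring on this carbon would stay level with these aryl compounds remains open.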